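The source may hold more compounds than are shown below. What is called first, only, known or untested is meant among the compounds shown, and "the series" means these compounds.

In a functional assay on Caco-2 cells (Homo sapiens), read by MTT assay, with a stated time of 48 h (on this read-out higher numbers stand for weaker inhibition and lower numbers for stronger inhibition), compound 1 `CCn1c(C(=O)NCCCN(C)C)ccc1C(CC)(CC)c1ccc(OCC(O)C(C)(C)C)c(C)c1` gives 1900 nM. Compound 2 `C#CC(C)OC(=O)c1ccc(C(CC)(CC)c2ccc(OCC(O)C(C)(C)C)c(C)c2)n1CC` gives > 50000 nM, which is a limit and not a number; it stands at the limit of > 50000 nM in this assay, at which 1 of the 2 values shown sits. Among the measured compounds shown here, the one measured step is an at least 26-fold higher number from compound 1 to compound 2 (1.42 log units; beyond the scatter). Compound 3 `CC[C@@H](C)[C@H](NC(=O)c1ccc(C(CC)(CC)c2ccc(OCC(O)C(C)(C)C)c(C)c2)n1CC)C(=O)O` brings ((1-carboxy-2-methylbutyl)amino in place of (1-methylprop-2-yn-1-yl)oxy on a carbonyl carbon). Compound 3 again has an amino group on that carbonyl carbon, as does compound 1 at 1900 nM, though it lacks the dimethylamino end, so only a partial return towards stronger inhibition is expected in this assay. The expected step is an at least 2.0-fold lower number from compound 2 to compound 3 (0.30 log units; that floor lies within the scatter). For compound 3 the estimated value is 25000 nM, with an expected range of 7000 nM to 80000 nM.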

Compound 3, half-maximal inhibitory concentration: 3400 nM
Compound 3: middle estimate off by 7.4-fold (0.87 log units), on the high side, outside the stated range (below it).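

Compound 2 stands at a limit and not a number: the limit of > 50000 nM in this assay, at which 1 of the 3 values shown sits. Putting (1-carboxy-2-methylbutyl)amino in place of (1-methylprop-2-yn-1-yl)oxy on the carbonyl carbon gives an at least 14-fold lower number from compound 2 to compound 3 (1.16 log units; beyond the scatter), so among these three compounds, stronger inhibition goes with an amide, with or without a dimethylamino end on the chain. Swapping 3-(dimethylamino)propyl for 1-carboxy-2-methylbutyl on the amide-type nitrogen gives a 1.8-fold higher number from compound 1 to compound 3 (0.25 log units; within the scatter), so these two different chains cannot be told apart here.

From the compounds shown here alone, how a plain ethyl chain on that nitrogen, or a methyl ester in place of the carboxylic acid, would read stays open.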